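Methyl for Chloro: a Small Change, Little Shift Expected

The source may report more compounds than this note shows. Statements on the series, on what has been measured and on what is new or still open speak of the compounds shown alone.

compound 1 `CC1(C)[C@H]2CC[C@]1(C)N(Cc1cn(-c3cccc(Cl)c3)nn1)C(=O)C2` — 260 nM
compound 2 `CC1(C)[C@H]2CC[C@]1(C)N(Cc1cn(-c3ccc(Br)cc3)nn1)C(=O)C2` — 200 nM

Among the two numbers measured in a functional assay on PANC-1 cells (Homo sapiens) for inhibition, read by MTT assay, with a stated time of 24 h (on this read-out higher numbers stand for weaker inhibition and lower numbers for stronger inhibition), compound 1 gives the highest one; its nearest neighbour is compound 2, reached by a 1.3-fold lower number from compound 1 to compound 2 (0.11 log units; within the scatter), a step that swaps 4-bromophenyl in for 3-chlorophenyl on an aromatic nitrogen. Compound 3 `Cc1cccc(-n2cc(CN3C(=O)C[C@@H]4CC[C@@]3(C)C4(C)C)nn2)c1` differs from compound 1 by methyl in place of chloro on an aromatic carbon. Among the compounds with values here, the only measured step touches the same phenyl ring and moves the number within the scatter, so the ring's substitution seems tolerant of variation in this set, though no measured step exchanges chloro for methyl directly. The step from compound 1 to compound 3 is therefore expected to stay within the scatter, no change at the digits printed from compound 1 to compound 3 (within the scatter). For compound 3 the estimate in this assay is 260 nM, with a plausible range from 120 nM to 600 nM.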

Compound 3, half-maximal inhibitory concentration: 240 nM
Compound 3: the middle estimate sits 1.1-fold (0.03 log units) above what was measured; low and high end bracket the measured number.
By their numbers in this assay, from the lowest: compounds 2, 3 and 1 (each within the scatter of the next).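

In this assay the exchange of chloro for methyl on this aromatic carbon can now be read directly: a 1.1-fold lower number from compound 1 to compound 3 (0.03 log units; within the scatter) shows that the two groups cannot be told apart at this position. The second new step, a 1.2-fold higher number from compound 2 to compound 3 (0.08 log units; within the scatter), adds 3-methylphenyl to the comparison with 4-bromophenyl, so that all three aryl groups on the aromatic nitrogen, 3-chlorophenyl included, lie within the scatter of one another. Nothing available explains this flat result. The compounds shown leave open whether the same holds for a group of another kind on this ring, such as an amine, a carboxylic acid or a longer alkyl chain. They also leave open whether methyl and chloro would stay equivalent on other carbons of the ring, or in any other assay.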